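The source may hold more compounds than are shown below. What is called first, only, known or untested is meant among the compounds shown, and "the series" means these compounds.

Series notes. Compound 1 `COc1cccc(C(=O)Nc2cccc(C(=O)O)c2)c1` in an assay on isolated protein for agonist activity at Bile acid receptor (Homo sapiens), read by TR-FRET, with a stated time of 3 h, in the absence of a further agent (on this read-out lower numbers stand for an effect already at smaller amounts and higher numbers for an effect only at larger amounts of compound), gives 1040 nM. For the measured compounds named here, compound 2 `CC(C)COc1cccc(C(=O)Nc2cccc(C(=O)O)c2)c1` in this assay gives 1130 nM; of the two numbers so far it sits at the upper end, but the step of a 1.1-fold higher number from compound 1 to compound 2 (0.04 log units; within the scatter) is within the scatter, so the two compounds cannot be told apart on this read-out.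

Compound 3 `Cc1ccc(COc2cccc(C(=O)Nc3cccc(C(=O)O)c3)c2)cc1` has not yet been measured in this assay. Its change from compound 2 is 4-methylphenyl in place of isopropyl on a saturated chain carbon bound to an oxygen on an aromatic ring. Going by the values given here, only one measured step touches this place, a 1.1-fold higher number from compound 1 to compound 2 (0.04 log units; within the scatter), and it was flat. That step put isopropyl where hydrogen had been; the present step puts 4-methylphenyl where isopropyl is, so the earlier step is a partial guide only. Among the compounds with values here, no measured pair carries a 4-methylphenyl group, and the direction of the change is therefore open.

Given the flat earlier step, a 1.3-fold lower number from compound 2 to compound 3 (0.12 log units; within the scatter) is expected to stay within, or only just beyond, the scatter. The estimate for compound 3 is 850 nM, with a range from 300 nM to 2500 nM.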

Compound 3, half-maximal effective concentration: 1430 nM
For compound 3 the middle estimate is 1.7-fold (0.23 log units) below the measured one; measured number inside the range.
By their numbers in this assay, from the lowest: compounds 1, 2 and 3 (each within the scatter of the next).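

Across the three groups at this place, on a saturated chain carbon bound to an oxygen on an aromatic ring, the read-out in this assay does not separate a ring from a branched chain: the change shows a 1.3-fold higher number from compound 2 to compound 3 (0.10 log units; within the scatter). The wider comparison with hydrogen at the same place shows a 1.4-fold higher number from compound 1 to compound 3 (0.14 log units; within the scatter), so even 4-methylphenyl, with 7 heavy atoms and one six-membered aromatic ring, gives no step beyond the scatter, and none of the three compounds goes against this flat picture. No measurement at hand explains why the numbers stay so close.

The compounds shown leave open whether any group at this place can move the number beyond the scatter in either direction, for instance a chain ending in an amine or in a carboxylic acid, or a longer chain. They also leave open whether the methyl of 4-methylphenyl contributes anything, since a plain phenyl group, which would isolate that methyl, does not appear among them.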